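A Fluoro Substituent Tested Against a Cytotoxicity Limit

The compounds below may be only part of what the source reports. "The series", "measured", "known", "first", "only" and "open" are said of these compounds alone.

Compound 1 `S=C(Nc1ccccc1)Nc1nc2c(Cl)cccc2s1`: in a functional assay on U-937 cells (Homo sapiens) for cytotoxicity, read by MTT assay, with a stated time of 48 h (a lower number here means a stronger inhibitor, a higher number a weaker inhibitor), compound 1 gives > 50000 nM, which is a limit of the assay.
Compound 2 `Cc1ccc2nc(NC(=S)Nc3ccccc3)sc2c1`: in this assay compound 2 gives > 50000 nM, again a limit.
Compound 3 `Cc1ccc2nc(NC(=S)Nc3ccc(F)cc3)sc2c1`: in this assay compound 3 gives > 50000 nM, again a limit.

Compound 2 and compound 3 differ in one place, (fluoro in place of hydrogen on an aromatic carbon). The step that the two limits leave unreadable from compound 2 to compound 3 cannot be read because of the limit of > 50000 nM in this assay, at which 3 of the 3 values shown sit. How the core of compound 1 differs from that of compound 2 is not broken down here.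

Compound 4 `Fc1ccc(NC(=S)Nc2nc3c(Cl)cccc3s2)cc1` has not yet been measured. Within the data shown here, it differs from compound 1 in one place, (fluoro in place of hydrogen on an aromatic carbon), and this is the same change as the one from compound 2 to compound 3, at the same place. Since the measured pair gives no readable step, the expectation for compound 4 rests only on compound 1 and its limit > 50000 nM: the step that the limit leaves unreadable from compound 1 to compound 4 is estimated to be small, and compound 4 is expected to give about 80000 nM, most likely reported again as a limit.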

Compound 4, half-maximal inhibitory concentration: > 50000 nM
Compound 4: a limit, no number; the forecaster's own chance of this, stated with the estimate: 85%; the middle value lies beyond the limit too.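

Among these compounds, compound 1 and compound 4 differ only by fluoro in place of hydrogen, yet no step between them can be read, because both give a limit and not a number: the limit of > 50000 nM in this assay, at which 4 of the 4 values shown sit.

The compounds shown leave open whether the change from phenyl to 4-fluorophenyl alters cytotoxicity at all, and how compound 1, compound 2, compound 3 and compound 4 truly compare.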